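Swapping Nitro for Amino on Two Related Cores

A few compounds are considered here, and "the series" means these few. Any claim that something is new, unique, unknown or untested is made for them only; others in the source may bear on it.

Compound 1 `O=[N+]([O-])c1ccc(-c2cc(-c3ccccc3)n[nH]2)cc1` and compound 2 `Nc1ccc(-c2cc(-c3ccccc3)n[nH]2)cc1` share one core and differ in a single place: amino in place of nitro on an aromatic carbon. In a functional assay on NCI-H460 cells (Homo sapiens) for inhibition, read by MTT assay, with a stated time of 48 h (on this read-out lower numbers stand for stronger inhibition of growth and higher numbers for weaker inhibition of growth), compound 1 gives 10200 nM, and compound 2 gives 26700 nM; the step is a 2.6-fold higher number from compound 1 to compound 2 (0.42 log units; beyond the scatter). Compound 3 `O=[N+]([O-])c1ccc(-c2cc(-c3ccccc3-c3ccccc3)n[nH]2)cc1` has a larger core than compound 1, the difference being (phenyl in place of hydrogen on an aromatic carbon); in this assay compound 3 gives 2700 nM, a step of a 3.8-fold lower number from compound 1 to compound 3 (0.58 log units; beyond the scatter). Compound 4 `Nc1ccc(-c2cc(-c3ccccc3-c3ccccc3)n[nH]2)cc1` stands to compound 3 as compound 2 stands to compound 1, the change being (amino in place of nitro on an aromatic carbon), at the same place with the same surroundings, so it is the same change. Since the earlier occurrence gave a 2.6-fold higher number from compound 1 to compound 2 (0.42 log units; beyond the scatter), a comparable weakening is expected here. For compound 4 the step is estimated as a 2.6-fold higher number from compound 3 to compound 4 (0.41 log units; beyond the scatter). In this assay compound 4 is expected to give about 7000 nM, likely between 3000 nM and 17000 nM.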

Compound 4, concentration for 50% growth inhibition: 8200 nM
Compound 4: middle estimate off by 1.2-fold (0.07 log units), on the low side; low and high end bracket the measured number.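

In this assay amino in place of nitro gives a 3.0-fold higher number from compound 3 to compound 4 (0.48 log units; beyond the scatter) and phenyl in place of hydrogen gives a 3.3-fold lower number from compound 2 to compound 4 (0.51 log units; beyond the scatter). Amino in place of nitro carries over from one core to the other at much the same size: the same change on two cores in this assay, a 2.6-fold higher number (0.42 log units; beyond the scatter) from compound 1 to compound 2 and a 3.0-fold higher number (0.48 log units; beyond the scatter) from compound 3 to compound 4, 1.2-fold (0.06 log units) apart, within the scatter of two such steps. Phenyl in place of hydrogen does so too, but four compounds in one assay give no general rule and do not say why the steps match: the same change on two cores in this assay, a 3.8-fold lower number (0.58 log units; beyond the scatter) from compound 1 to compound 3 and a 3.3-fold lower number (0.51 log units; beyond the scatter) from compound 2 to compound 4, 1.2-fold (0.06 log units) apart, within the scatter of two such steps. As far as these compounds go, whether a methoxy group or a carboxylic acid in place of the nitro would also shift the number by a similar amount on both cores remains open. So does whether a longer chain in place of the added phenyl would carry over in this way.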